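Anilino ring fluoro step from compound 2 to compound 4

The source may report more compounds than this note shows. Statements on the series, on what has been measured and on what is new or still open speak of the compounds shown alone.

compound 1 `COc1cccc(Nc2nc(N)c(C(=O)c3ccccc3)s2)c1`: 1500 nM
compound 2 `COc1cc(C(=O)c2sc(Nc3ccccc3)nc2N)cc(OC)c1OC`: 6 nM
compound 3 `COc1ccc(C(=O)c2sc(Nc3ccccc3)nc2N)cc1OC`: 5500 nM

All three values come from a functional assay on MOLT-4 cells (Homo sapiens) for antiproliferative activity, read by cell counting, with a stated time of 2 days; a higher number here means a weaker inhibitor, a lower number a stronger inhibitor. Compound 2 stands lowest of the three numbers, and so is the strongest inhibitor measured in this small set.

The next compound to be read is compound 4 `COc1cc(C(=O)c2sc(Nc3ccc(F)cc3)nc2N)cc(OC)c1OC`. Its difference from compound 2 is fluoro in place of hydrogen on an aromatic carbon. In words, this is fluoro in place of hydrogen on an aromatic carbon, para to a large group, or phenyl to 4-fluorophenyl.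

Among the measured compounds shown here, only one measured step is available, a 920-fold higher number from compound 2 to compound 3 (2.96 log units; beyond the scatter). It is large, but it is a loss of methoxy on the benzoyl side and does not touch the anilino group, so it sets no size for the present change. Compound 1 differs from compound 2 in more than one place and isolates nothing about the anilino group. For the measured compounds named here, no measured pair tests a substituent on the anilino group alone, which leaves the expectation loose.

A modest change is expected, more likely upward than downward in this assay, and it may not clear the scatter. The expected step is a 2.5-fold higher number from compound 2 to compound 4 (0.40 log units; beyond the scatter). For compound 4 the estimate is 15 nM, with an expected range of 3 nM to 80 nM.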

Compound 4, half-maximal inhibitory concentration: 280 nM
The estimate for compound 4 lay 19-fold (1.27 log units) below the measured number; measured number above the stated range.
By their numbers in this assay, from the lowest: compound 2; then compound 4; then compound 1; then compound 3.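

In this assay the hydrogen on this aromatic carbon of the anilino ring, para to a large group, proves far from indifferent to replacement: one fluoro, a single heavy atom, gives a 47-fold higher number from compound 2 to compound 4 (1.67 log units; beyond the scatter) in a step printed as large. Among the compounds shown here, the only earlier single-place step, a 920-fold higher number from compound 2 to compound 3 (2.96 log units; beyond the scatter) on the benzoyl side, said nothing about the anilino ring, so the high potency of compound 2 now appears to depend on both sides of the shared core, each side resting on a single pair. No measurement here accounts for the weakening, and the size of the fluoro step stays unexplained.

From the compounds shown here alone, whether the weakening belongs to fluoro itself or would follow any group on this carbon remains open, and chloro, methyl or dimethylamino at the same place, each set against compound 2, would separate those two readings. Also open, going by these compounds, is whether fluoro on another carbon of the anilino ring would cost as much, since compound 1 differs from compound 2 in more than one place and cannot settle that.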